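The compounds below may be only part of what the source reports. "The series", "measured", "known", "first", "only" and "open" are said of these compounds alone.

Measured so far in a functional assay on OVCAR-5 cells (Homo sapiens) for inhibition, read by sulforhodamine B assay, with a stated time of 48 h (a higher number here means a weaker inhibitor of growth, a lower number a stronger inhibitor of growth), for this series:
- compound 1 `Cc1cn([C@H]2C[C@H](CC3=CC(=O)C(=O)C=C3)[C@@H](CO[Si](C)(C)C(C)(C)C)O2)c(=O)[nH]c1=O` has no result reported
- compound 2 `COc1ccc(C2([C@H]3C[C@H](n4cc(C)c(=O)[nH]c4=O)O[C@@H]3CO[Si](C)(C)C(C)(C)C)SCCCS2)cc1OC` gives 2880 nM

Within the data shown here, compound 2 holds the only number, so it cannot yet be ranked against another compound. Compound 1 offers no comparison. Not yet measured is compound 3 `COc1ccc(C2([C@H]3C[C@@H](n4cc(C)c(=O)[nH]c4=O)O[C@@H]3CO[Si](C)(C)C(C)(C)C)SCCCS2)cc1OC`, which has the same atoms and bonds as compound 2 and differs only in configuration as drawn (the two compounds have the same atoms and bonds and differ only in configuration as drawn: 1 of 3 stereo elements differ; a stereocentre at a saturated ring carbon is drawn R in compound 2 and S in compound 3). Among the measured compounds shown here, no measured step shows what such a change does in this assay, so the expectation rests only on compound 2 at 2880 nM and is deliberately wide. No step beyond the usual scatter is expected, and neither direction is favoured. The expected step is a 1.0-fold higher number from compound 2 to compound 3 (0.02 log units; within the scatter) on this reading. For compound 3 the estimated value is 3000 nM with an expected range from 1200 nM to 8000 nM until a measurement is available.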

Compound 3, concentration for 50% growth inhibition: 12900 nM
The estimate for compound 3 lay 4.3-fold (0.63 log units) below the measured number; measured number above the stated range.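

In this assay the stereocentre at the saturated ring carbon is not neutral: changing it from R as drawn to S gives a 4.5-fold higher number from compound 2 to compound 3 (0.65 log units; beyond the scatter). Among these compounds, this is the first step that can be read, and within this single pair the R configuration goes with the stronger growth inhibition. The step can be traced to this stereocentre alone because of one fact: the fact that compounds 2 and 3 differ only in the configuration as drawn.

The pair does not show how the configuration acts on growth inhibition, nor whether the same preference would hold in other cell lines. Also open, going by these compounds, is whether it would persist with a different group on the shared core, such as an amine or a carboxylic acid.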